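Shortening the hydroxycarbamoyl chain of compound 1

The source may report more compounds than this note shows. Statements on the series, on what has been measured and on what is new or still open speak of the compounds shown alone.

Values so far in a toxicity assay on Vero cells (Chlorocebus sabaeus) for inhibition, read by MTT assay, with a stated time of 72 h (on this read-out higher numbers stand for weaker inhibition and lower numbers for stronger inhibition), are these:
- Compound 1 `Cc1ccc(-c2cc(C(=O)NCCCCCCC(=O)NO)nn2-c2ccc(S(N)(=O)=O)cc2)cc1` gives > 100000 nM (a limit, not a number)
- Compound 2 `COC(=O)Cc1c(C)n(Cc2ccc(-c3cn(CCCCCCCC(=O)NO)nn3)cc2)c2ccc(OC)cc12` gives 5730 nM (a measured number)
- Compound 3 `Cc1ccc(-c2cc(C(=O)NCCCCCC(=O)NO)nn2-c2ccc(S(N)(=O)=O)cc2)cc1` has no value yet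

Compound 1 sits at the limit of > 100000 nM in this assay, at which 1 of the 2 values shown sits, so its entry is a limit and not a number. Within the data shown here, no two measured compounds differ in one place alone, so no measured step can guide the expectation. Compound 3 has a shorter chain than compound 1: hydroxycarbamoyl in place of (hydroxycarbamoyl)methyl on a saturated chain carbon, five bonds along the chain from an amide-type nitrogen. The expectation rests on compound 1 with its limit of > 100000 nM as the only anchor. The expected change is a number no higher from compound 1 to compound 3 (the limit leaves the size open), with no shift in either direction beyond the usual scatter. For compound 3 the estimate is 100000 nM, with an expected range from 40000 nM to 250000 nM as its ends.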

Compound 3, half-maximal inhibitory concentration: > 100000 nM
Compound 3: only a limit was reported; the forecaster's own chance of this, stated with the estimate: 65%; the middle value sits exactly at the limit.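

No step can be read from compound 1 to compound 3 in this assay, because the entries for both compounds are limits and not numbers: the limit of > 100000 nM in this assay, at which 2 of the 3 values shown sit.

The compounds shown leave open whether the shorter chain of compound 3 changes the read-out at all.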